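The source may hold more compounds than are shown below. What is called first, only, known or untested is meant among the compounds shown, and "the series" means these compounds.

In an ADME assay on a cell-free system (plasma, Homo sapiens) for protein binding, using equilibrium dialysis, two compounds have been measured so far. Compound 1 `CN(C)c1noc(-c2cccc(CN(C)c3ccc4[nH]nc(C(=O)O)c4c3)c2O)n1` reads > 99.8%, which is a limit of the assay and not a number. Within the data shown here, compound 2 `CN(C)c1noc(-c2cccc(CNc3ccc4[nH]nc(C(=O)O)c4c3)c2)n1` gives 99.1%, the only actual number available, so there is no second number to rank it against. Compound 3 `CN(C)c1noc(-c2cccc(CNc3ccc4[nH]nc(C(=O)O)c4c3)c2Cl)n1` differs from compound 2 by a single change, chloro in place of hydrogen on an aromatic carbon, ortho to a 3-(dimethylamino)-1,2,4-oxadiazol-5-yl group. Among the measured compounds shown here, no step between measured compounds gives a size for this change, so the expectation remains loose: a small move towards more bound compound, not clearly beyond the usual scatter. The expected step is a 1.8-fold lower unbound fraction from compound 2 to compound 3 (0.26 log units; within the scatter). Compound 3 is estimated at 99.5%, with an expected range from 99% to 99.8%.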

Compound 3, plasma protein binding in the Homo sapiens assay: 99.9%
Beside the measured number, compound 3's estimate is 5.0-fold (0.70 log units) (unbound fraction) above it, outside the stated range (above it).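

Chloro in place of hydrogen on an aromatic carbon, ortho to a 3-(dimethylamino)-1,2,4-oxadiazol-5-yl group, now has a measured size in the Homo sapiens assay: a 9.0-fold lower unbound fraction from compound 2 to compound 3 (0.95 log units; beyond the scatter). Compound 1 could not give this size: in the Homo sapiens assay compound 1 reads > 99.8%, a limit of the assay and not a number, and it differs from compound 2 in more than one place. The same exchange also shows up in a physicochemical assay for solubility, measured as kinetic solubility, at pH 2 (on this read-out higher numbers stand for higher solubility and lower numbers for lower solubility), so this one position moves two read-outs, and the second of them by a large step: the measured solubility of compound 2, 308000 nM, and of compound 3, 7000 nM, a 44-fold lower number (1.64 log units; beyond the scatter). In the physicochemical assay compound 2 gives 308000 nM and compound 3 gives 7000 nM.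

Going by these compounds, whether fluoro, methyl, methoxy or an amine on this carbon would move the two read-outs together, or separate them, remains open. A single pair cannot show whether the step found here would hold on other members of the series.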